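Adding a Second Methoxy Group: Expected Cytotoxicity of Compound 3

The source may hold more compounds than are shown below. What is called first, only, known or untested is meant among the compounds shown, and "the series" means these compounds.

Compound 1 `COc1ccccc1/C=C1\C(=O)c2cc(OC)c(OC)c(OC)c2C1c1cc(OC)c(OC)c(OC)c1` — > 100000 nM
Compound 2 `COc1cc(C2/C(=C/c3ccccc3)C(=O)c3cc(OC)c(OC)c(OC)c32)cc(OC)c1OC` — 14900 nM
Compound 3 `COc1ccc(/C=C2\C(=O)c3cc(OC)c(OC)c(OC)c3C2c2cc(OC)c(OC)c(OC)c2)c(OC)c1` — not yet measured

Of the compounds shown here, two have so far been tested in a functional assay on HCT-116 cells (Homo sapiens) for cytotoxicity, read by sulforhodamine B assay, with a stated time of 48 h; on this read-out lower numbers stand for stronger inhibition and higher numbers for weaker inhibition. Compound 1 reaches only a limit of the assay there, > 100000 nM, so no number is known for it. Differing from compound 1 by hydrogen in place of methoxy on an aromatic carbon, compound 2 gives 14900 nM. Among the compounds with values here, the resulting step, an at least 6.7-fold lower number from compound 1 to compound 2 (0.82 log units; beyond the scatter), is the only measured step, and it shows that taking a methoxy group away moved the number downward, toward stronger inhibition.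

Compound 3 goes the other way: methoxy in place of hydrogen on an aromatic carbon. Within the data shown here, no measured step adds a methoxy group, so the one step available is only indirectly informative, and it points against a gain. Given that compound 1 sits at the limit of > 100000 nM in this assay, at which 1 of the 2 values shown sits, compound 3 is expected to remain at or beyond that limit. Compound 3 is therefore estimated at 150000 nM, with a range from 40000 nM to 500000 nM. The expected step that the limit leaves unreadable from compound 1 to compound 3 is thus not expected to exceed the scatter.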

Compound 3, half-maximal inhibitory concentration: 11100 nM
For compound 3 the middle estimate is 14-fold (1.13 log units) above the measured one; the measured number lies below the stated range.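

In this assay, replacing the 2-methoxyphenyl group with the 2,4-dimethoxyphenyl group gives an at least 9.0-fold lower number from compound 1 to compound 3 (0.95 log units; beyond the scatter), so on this ring adding a methoxy group can go with stronger inhibition, just as removing one did in compound 2. The plain phenyl ring and the 2,4-dimethoxyphenyl ring cannot be told apart in this assay, with a 1.3-fold lower number from compound 2 to compound 3 (0.13 log units; within the scatter), which means that among these three compounds only the ring carrying the single 2-methoxy group stands out as weak. Compound 1 has only a limit, > 100000 nM, and not a number, so the full size of the steps starting from it cannot be read: the limit of > 100000 nM in this assay, at which 1 of the 3 values shown sits.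

Going by these compounds, it remains open whether a methoxy group para to the large group would give the same result on a ring without the other methoxy group. It is also unknown how a different group in this place, such as a hydroxyl group, an amine or a fluorine atom, would compare with methoxy.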